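Swapping the aminophenyl of compound 1 for a dichlorophenyl

A few compounds are considered here, and "the series" means these few. Any claim that something is new, unique, unknown or untested is made for them only; others in the source may bear on it.

Of the compounds shown here, two sharing one core have been measured for how much of each cell line tolerates. Compound 1 `COc1cc(-c2cc(/C=C/C(=O)c3ccc(N)cc3)[nH]n2)cc(OC)c1OC` is tested in a functional assay on M14 cells (Homo sapiens) for inhibition, read by sulforhodamine B assay, with a stated time of 48 h (a higher number here means that more compound is tolerated, a lower number that less compound is tolerated), and gives 8170 nM. Compound 2 `COc1ccc(-c2cc(/C=C/C(=O)c3ccc(OC)c(OC)c3)[nH]n2)cc1` gives in this assay a value of 13800 nM. Compound 1 has the lower of the two numbers, but the gap to compound 2 lies within the usual scatter of repeated measurements, so the two cannot be ranked against each other.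

Compound 3 `COc1cc(-c2cc(/C=C/C(=O)c3ccc(Cl)c(Cl)c3)[nH]n2)cc(OC)c1OC` has not yet been measured. It differs from compound 1 in one place: 3,4-dichlorophenyl in place of 4-aminophenyl on a carbonyl carbon. Within the data shown here, no measured pair shows the effect of such a swap, so there is nothing to anchor a direction. Among the measured compounds shown here, the two measured compounds also differ from each other in more than one place, which leaves no single step to copy.

Given this, the step from compound 1 to compound 3 is expected to stay within the scatter, with a 1.2-fold lower number from compound 1 to compound 3 (0.07 log units; within the scatter) as the working guess. Compound 3 is therefore estimated to give about 7000 nM in this assay, somewhere between 2500 nM and 20000 nM.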

Compound 3, concentration lethal to 50% of the cells: > 100000 nM
Compound 3: no number, only a limit; the forecaster's own chance of this, stated with the estimate: 10%; middle value at least 14-fold (1.15 log units) from the limit.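

On this carbonyl carbon, replacing 4-aminophenyl with 3,4-dichlorophenyl gives in this assay an at least 12-fold higher number from compound 1 to compound 3 (1.08 log units; beyond the scatter), so much more of the dichlorophenyl compound is tolerated, and this single-place step shows that the group at this position can matter a great deal. Compound 3 gives > 100000 nM, which is a limit of the assay and not a number. The step therefore marks only a minimum and not a full size, because one end of it rests on that limit: the limit of > 100000 nM in this assay, at which 1 of the 3 values shown sits.

What remains open is which part of the swap carries the step, as the amine leaves and the two chlorines enter in the same move, and the data give no measured property that could explain it. A plain phenyl on the same carbonyl carbon would help to pull these two parts apart, while a hydroxyl or a carboxylic acid on that ring would show whether the amine can be replaced by another group.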